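The compounds below may be only part of what the source reports. "The series", "measured", "known", "first", "only" and "open" are said of these compounds alone.

Measured in a functional assay, read by fluorescence and spectrophotometry, with a stated time of 1 h; a lower number here means that less compound is needed, a higher number that more compound is needed for the effect:
- compound 1 `CCCCCCCCCCCCS(=O)(=O)/C=C/c1ccc(O)c(O)c1` gives 8500 nM
- compound 2 `C=CCCCCCCS(=O)(=O)/C=C/c1ccc(O)c(O)c1` gives 6400 nM
- compound 3 `O=S(=O)(/C=C/c1ccc(O)c(O)c1)CCC1CCCC1` gives 6800 nM

Compound 3 at 6800 nM lies within the scatter of both other compounds, so these numbers set no order among the three. Compound 4 `CCCCCCCCCS(=O)(=O)/C=C/c1ccc(O)c(O)c1` carries heptyl in place of cyclopentyl on a saturated chain carbon, two bonds along the chain from a sulfonyl sulfur, with this count: heptyl in place of cyclopentyl on a saturated chain carbon, two bonds along the chain from a sulfonyl sulfur. Among the compounds with values here, two measured steps bear on this change. They are a 1.3-fold lower number from compound 1 to compound 2 (0.12 log units; within the scatter) and a 1.1-fold higher number from compound 2 to compound 3 (0.03 log units; within the scatter), the second at the same place, and both stay within the scatter. No step beyond the scatter is therefore expected in this assay. The expected step is a 1.0-fold higher number from compound 3 to compound 4 (0.01 log units; within the scatter) and would stay within the scatter. For compound 4 the estimated value is 7000 nM with an expected range from 4000 nM to 12000 nM for the measurement.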

Compound 4, half-maximal effective concentration: 7700 nM
For compound 4 the middle estimate is 1.1-fold (0.04 log units) below the measured one; low and high end bracket the measured number.
By their numbers in this assay, from the lowest: compounds 2, 3, 4 and 1 (each within the scatter of the next).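

In this assay heptyl in place of cyclopentyl, on a saturated chain carbon two bonds along the chain from a sulfonyl sulfur, stays within the scatter (a 1.1-fold higher number from compound 3 to compound 4 (0.05 log units; within the scatter)), so losing the ring shifts nothing that these numbers can resolve. Further along the chain, propyl in place of vinyl (a 1.2-fold higher number from compound 2 to compound 4 (0.08 log units; within the scatter)) and hydrogen in place of propyl (a 1.1-fold lower number from compound 1 to compound 4 (0.04 log units; within the scatter)) also stay within the scatter. From the compounds shown here alone, whether an amine, a carboxylic acid or a much longer chain at this place would give a step beyond the scatter remains open. Nothing available explains why these carbon-only groups read alike.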